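The compounds below may be only part of what the source reports. "The series", "measured", "known", "first", "only" and "open" are said of these compounds alone.

In a functional assay on HCT-116 cells (Homo sapiens) for cytotoxicity, read by MTT assay, with a stated time of 48 h (a higher number here means a weaker inhibitor, a lower number a stronger inhibitor), compound 1 (`COc1cc(/C=C/C(=O)C2=C(/C=C/c3ccc(O)c(OC)c3)NC(=O)NC2c2c(Cl)cccc2Cl)ccc1O`) gives 50000 nM and compound 2 (`COc1cc(/C=C/C(=O)C2=C(/C=C/c3ccc(O)c(OC)c3)NC(=S)NC2c2ccc(C)cc2)ccc1O`) gives 50000 nM as its value, so compound 2 stands level with compound 1. Compound 3 (`COc1cc(/C=C/C(=O)C2=C(/C=C/c3ccc(O)c(OC)c3)NC(=S)NC2c2c(Cl)cccc2Cl)ccc1O`) has 2,6-dichlorophenyl in place of 4-methylphenyl on a saturated ring carbon. Among the measured compounds shown here, no measured pair shows this swap alone, so the expectation in this assay rests on compound 1 at 50000 nM and compound 2 at 50000 nM and is for no change beyond the scatter. The expected size is no change at the digits printed from compound 2 to compound 3 (within the scatter) on this estimate. Compound 3 is estimated at 50000 nM with an expected range from 20000 nM to 100000 nM in this test.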

Compound 3, half-maximal inhibitory concentration: 50000 nM
Estimate against measurement, compound 3: no gap at the digits printed; low and high end bracket the measured number.
By their numbers in this assay, from the lowest: compounds 1, 2 and 3 (each within the scatter of the next).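

Among the compounds shown here, putting 2,6-dichlorophenyl in place of 4-methylphenyl on the saturated ring carbon gives no change at the digits printed from compound 2 to compound 3 (within the scatter) in this assay, the first direct reading of this swap at this position. At this position, then, these two substituted phenyl groups cannot be told apart in this test. Nothing available explains this result.

Still open, on these data alone, is whether a 4-hydroxyphenyl group, a 4-aminophenyl group or a longer alkyl chain on this carbon would read differently from compound 3 at 50000 nM.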